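Chloro removal across two cores in a growth-inhibition series

A few compounds are considered here, and "the series" means these few. Any claim that something is new, unique, unknown or untested is made for them only; others in the source may bear on it.

In a functional assay on DU-145 cells (Homo sapiens) for inhibition, read by trypan blue exclusion, with a stated time of 96 h (on this read-out lower numbers stand for stronger inhibition of growth and higher numbers for weaker inhibition of growth), compound 1 `Cc1ccsc1/C=C(/SCc1ccc(Cl)cc1)C(=O)c1ccc(Cl)cc1` gives 50000 nM and compound 2 `Cc1ccsc1/C=C(/SCc1ccc(Cl)c(Cl)c1)C(=O)c1ccc(Cl)cc1` gives 50000 nM. The change from compound 2 to compound 1 is hydrogen in place of chloro on an aromatic carbon, and its size is no change at the digits printed from compound 2 to compound 1 (within the scatter). Compound 3 `Cc1ccc(S(=O)(=O)/C(=C/c2c[nH]c3ccc(Cl)cc23)C(=O)c2ccc(Br)cc2)cc1` is built on a different core; the difference between the two cores is not broken down here. In this assay compound 3 gives 10000 nM, the lowest of the three numbers, beyond the scatter from compound 1 and from compound 2.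

Compound 4 `Cc1ccc(S(=O)(=O)/C(=C/c2c[nH]c3ccccc23)C(=O)c2ccc(Br)cc2)cc1` differs from compound 3 by hydrogen in place of chloro on an aromatic carbon. This is the same kind of change as that from compound 2 to compound 1, but the place differs: there the carbon sits ortho to a chloro group and meta to a large group, here it is part of a fused system of two rings, meta to a fused ring and para to a fused ring. Since compound 2 to compound 1 gave no change at the digits printed from compound 2 to compound 1 (within the scatter), the step is expected to be a 1.5-fold higher number from compound 3 to compound 4 (0.18 log units; within the scatter). Compound 4 is estimated at 15000 nM, between 5000 nM and 50000 nM.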

Compound 4, concentration for 50% growth inhibition: 10000 nM
Beside the measured number, compound 4's estimate is 1.5-fold (0.18 log units) above it, within the range that was stated.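

Taking chloro off the aromatic carbon of compound 3, 5-chloro-1H-indol-3-yl to 1H-indol-3-yl, gives no change at the digits printed from compound 3 to compound 4 (within the scatter) in this assay. In this series, the same change therefore reads alike on the two cores: the same change on two cores in this assay, no change at the digits printed (within the scatter) from compound 2 to compound 1 and no change at the digits printed (within the scatter) from compound 3 to compound 4, 1.0-fold (0.00 log units) apart, within the scatter of two such steps. This rests on one pair per core, with the chloro at a different place in each, and both steps are flat, so it shows agreement only for these two places and does not show that a step of visible size would carry from one core to the other.

The compounds shown leave open whether a methoxy group, an amine or a carboxylic acid on the same aromatic carbon would move the number on either core. They also leave open whether hydrogen in place of the bromo group of compound 4 would read like the two chloro steps.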